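Two Inactive Ketones and a Phenyl Replacement

The source may hold more compounds than are shown below. What is called first, only, known or untested is meant among the compounds shown, and "the series" means these compounds.

Compound 1, `O=C(CCCCCCc1ccccc1)c1ncc(-c2cccs2)s1`: in an assay on HEK-293T cells for inhibition of diacylglycerol lipase-alpha (Homo sapiens), read by colorimetric assay (a higher number here means a weaker inhibitor, a lower number a stronger inhibitor), compound 1 gives > 10000 nM, which is a limit of the assay and not a number.
Compound 2, `O=C(CCCCCCc1ccccc1)c1nnc(-c2ccco2)s1`: in this assay compound 2 gives > 10000 nM, again only a limit.

Compound 2 therefore stands on no number at all. For the measured compounds named here, both values shown sit at the limit of > 10000 nM in this assay, at which 2 of the 2 values shown sit, and no step between measured compounds can be drawn from them; the two values show only that neither compound reaches the measurable range of this assay.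

Compound 3, `O=C(CCCCCCc1ccccc1)c1nnc(-c2ccccc2)s1`, differs from compound 2 by phenyl in place of furan-2-yl on an aromatic carbon. Going by the values given here, with no measured step to rest on, no change beyond the scatter is expected in this assay. The expected step is a step that the limit leaves unreadable from compound 2 to compound 3. Compound 3 is expected to give about 15000 nM. Compound 3 is expected most likely to return only a limit again, with any number falling between 3000 nM and 60000 nM.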

Compound 3, half-maximal inhibitory concentration: > 10000 nM
Compound 3 ended at the assay's limit (the forecaster's own chance of this, stated with the estimate: 75%); the middle value does not contradict the limit.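

For the compounds shown here, compound 3, like compound 2, returns only a limit, so no step between them can be read from the swap of furan-2-yl for phenyl: the limit of > 10000 nM in this assay, at which 3 of the 3 values shown sit. The compounds shown leave open whether any change to the shared core would give a number in this assay rather than a limit.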